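Ring fusion at the amine substituent of a quinolone acid

This account rests on a few compounds, and the source may have more. Where it says the series, first, only, none or still open, it means among the compounds named here.

Compound 3 `O=C(O)c1cn(Cc2ccc(-c3ccccc3)cc2)c2cc(NC[C@H]3CCNC3)c(F)cc2c1=O` is one of three congeners on a shared core; in an assay on isolated protein for inhibition of DNA topoisomerase 1 (Homo sapiens), with a stated time of 15 min (a lower number here means a stronger inhibitor, a higher number a weaker inhibitor), compound 3 gives 100000 nM. Compound 1 `NCCNc1cc2c(cc1F)c(=O)c(C(=O)O)cn2Cc1ccc(-c2ccccc2)cc1` gives 72800 nM, and compound 2 `O=C(O)c1cn(Cc2ccc(-n3cccn3)cc2)c2cc(NC[C@H]3CCNC3)c(F)cc2c1=O` gives 187000 nM. Compound 3 thus holds the second of the three numbers, yet both gaps are within the scatter: a 1.4-fold higher number from compound 1 to compound 3 (0.14 log units; within the scatter) and a 1.9-fold lower number from compound 2 to compound 3 (0.27 log units; within the scatter). Compound 4 `O=C(O)c1cn(Cc2ccc(-c3ccccc3)cc2)c2cc(N3C[C@H]4CCNC[C@H]4C3)c(F)cc2c1=O` differs from compound 3 at the amine substituent: a group of 9 heavy atoms (7 carbon, 2 nitrogen; one five-membered non-aromatic ring with 1 hetero atom, one six-membered non-aromatic ring with 1 hetero atom) in place of a group of 7 heavy atoms (5 carbon, 2 nitrogen; one five-membered non-aromatic ring with 1 hetero atom), on an aromatic carbon. Within the data shown here, of the measured steps, only the one from compound 1 to compound 3 concerns this same site, and it stayed within the scatter; the other step concerned a different site and was likewise small. Nothing in the series points to a shift beyond the scatter, so the step in this assay from compound 3 to compound 4 is expected to be close to flat, no change at the digits printed from compound 3 to compound 4 (within the scatter). Compound 4 is therefore estimated at 100000 nM, with a range from 30000 nM to 300000 nM.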

Compound 4, half-maximal inhibitory concentration: 61000 nM
Estimate against measurement, compound 4: 1.6-fold (0.21 log units) above, within the range that was stated.
By their numbers in this assay, from the lowest: compounds 4, 1, 3 and 2 (each within the scatter of the next, the first and the last beyond it).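

With the two-ring group in compound 4, the amine substituent grows without a step beyond the scatter in this assay: there is a 1.6-fold lower number from compound 3 to compound 4 (0.21 log units; within the scatter) and also a 1.2-fold lower number from compound 1 to compound 4 (0.08 log units; within the scatter). The open chain of compound 1, the ((pyrrolidin-3-yl)methyl)amino group of compound 3 and the two-ring group of compound 4 therefore all lie within the scatter of one another, so this position shows no order among these three groups, even with the added six-membered non-aromatic ring. Nothing at hand bears on why the numbers stay so close.

Still open, as far as these compounds go, is whether a piperazine or a morpholine on this aromatic carbon would remain in the same range, and whether the opposite stereoisomer of the two-ring group would do so. Also open, from the compounds shown here alone, is how the two-ring group behaves alongside the 1H-pyrazol-1-yl group of compound 2.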